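Pyridin-4-yl replacement carried from one core to another

This account rests on a few compounds, and the source may have more. Where it says the series, first, only, none or still open, it means among the compounds named here.

Measured in an assay on microsomes from brain for inhibition of Fatty-acid amide hydrolase 1 (Rattus norvegicus), read by fluorescence and HPLC, with a stated time of 60 min; a lower number here means a stronger inhibitor, a higher number a weaker inhibitor:
- compound 1 `CCCCCCCCc1ccc(OCC(=O)Cn2nnc(-c3cccc(S(=O)(=O)N(C)C)c3)n2)cc1` gives 420 nM
- compound 2 `CCCCCCCCc1ccc(OCC(=O)Cn2nnc(-c3ccncc3)n2)cc1` gives 24 nM
- compound 3 `CCCCCCCCc1ccc(OCC(=O)Cn2nnnc2-c2cccc(S(=O)(=O)N(C)C)c2)cc1` gives 1900 nM

The change pyridin-4-yl in place of 3-(dimethylsulfamoyl)phenyl on an aromatic carbon produced an 18-fold lower number from compound 1 to compound 2 (1.24 log units; beyond the scatter). Compound 3 has the same atoms as compound 1 joined differently; the difference between the two cores is not broken down here, and compound 3 stands highest of the three numbers.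

Compound 4 `CCCCCCCCc1ccc(OCC(=O)Cn2nnnc2-c2ccncc2)cc1`, not yet measured, carries the same kind of change on the core of compound 3: pyridin-4-yl in place of 3-(dimethylsulfamoyl)phenyl on an aromatic carbon. The place is not identical: in compound 3 the site is next to the ring atom that bears a large group, whereas in compound 1 it is two ring bonds from the ring atom that bears a large group.

For compound 4 in this assay a step of a 17-fold lower number from compound 3 to compound 4 (1.24 log units; beyond the scatter) is expected. Among the measured compounds shown here, this expectation rests only on the single earlier step of an 18-fold lower number from compound 1 to compound 2 (1.24 log units; beyond the scatter), made on a different core. The estimate for compound 4 is 110 nM, expected between 35 nM and 400 nM.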

Compound 4, half-maximal inhibitory concentration: 190 nM
For compound 4 the middle estimate is 1.7-fold (0.24 log units) below the measured one; the range from low to high includes it.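

In this assay, putting pyridin-4-yl in place of 3-(dimethylsulfamoyl)phenyl on the core of compound 3 again lowers the number, giving a 10-fold lower number from compound 3 to compound 4 (1.00 log units; beyond the scatter). Set beside the step on the other core, the size of the change holds up: the same change on two cores in this assay, an 18-fold lower number (1.24 log units; beyond the scatter) from compound 1 to compound 2 and a 10-fold lower number (1.00 log units; beyond the scatter) from compound 3 to compound 4, 1.8-fold (0.24 log units) apart, within the scatter of two such steps. This shows that the change carried across these two cores in the same direction, but with one pair per core, it says nothing about any further core or about why the two cores differ.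

Still open, on these data alone, is whether other groups at this place, such as a plain phenyl or a phenyl carrying a carboxylic acid, would also give matching steps on both cores.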